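Extending the Linker Once More: Expected Cytotoxicity

This account rests on a few compounds, and the source may have more. Where it says the series, first, only, none or still open, it means among the compounds named here.

For the measured compounds named here, compound 3 `Cc1ncc([N+](=O)[O-])n1CCCCCN1CCN(c2ccnc3cc(Cl)ccc23)CC1` is the only compound of the three measured for which an ADME assay on J774 cells (Mus musculus) for cytotoxicity, read by resazurin assay, with a stated time of 24 h (a higher number here means a weaker inhibitor, a lower number a stronger inhibitor), gives a number: compound 3 gives 28.9 ug/mL. Compound 1 `Cc1ncc([N+](=O)[O-])n1CCCCCN1CCCCC1` reaches only the limit of the assay, at > 100 ug/mL. Compound 2 `Cc1ncc([N+](=O)[O-])n1CCCCN1CCN(c2ccnc3cc(Cl)ccc23)CC1` likewise reaches only the limit, at > 100 ug/mL. Going by the values given here, two of the three values are thus (the limit of > 100 ug/mL in this assay, at which 2 of the 3 values shown sit), and compound 3 stands as the one compound whose cytotoxicity could be quantified.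

Compound 4 `Cc1ncc([N+](=O)[O-])n1CCCCCCN1CCN(c2ccnc3cc(Cl)ccc23)CC1` differs from compound 3 by (2-methyl-5-nitro-1H-imidazol-1-yl)methyl in place of 2-methyl-5-nitro-1H-imidazol-1-yl on a saturated chain carbon, five bonds along the chain from an amine nitrogen in a ring. Among the compounds with values here, the one measured step that bears on this change is the same kind of lengthening of the chain, an at least 3.4-fold lower number from compound 2 to compound 3 (0.53 log units; beyond the scatter). As far as these compounds go, that step crossed from a limit to a number, so its true size is unknown; it lowered the number by at least a modest amount. Repeating the lengthening once more could continue in that direction, but a single step gives no firm pattern, and a step within the scatter is also possible. A modest further lowering is expected for compound 4, a 1.4-fold lower number from compound 3 to compound 4 (0.16 log units; within the scatter). Compound 4 is therefore estimated at 20 ug/mL, with a range from 8 ug/mL to 50 ug/mL.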

Compound 4, half-maximal inhibitory concentration: < 0.8 ug/mL
Compound 4: a limit, no number; the forecaster's own chance of this, stated with the estimate: 10%; at least 25-fold (1.39 log units) between middle value and limit.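

In this assay, the lengthened chain gives an at least 36-fold lower number from compound 3 to compound 4 (1.55 log units; beyond the scatter), which runs in the same direction as an at least 3.4-fold lower number from compound 2 to compound 3 (0.53 log units; beyond the scatter), so across compound 2, compound 3 and compound 4 each added carbon on the chain lowers the number by more than the scatter. As far as these compounds go, compound 4 stands at a limit, not a number, so the true size of this step remains unknown: the limit of < 0.8 ug/mL in this assay, at which 1 of the 4 values shown sits. The earlier compounds shown here could not show that the fall continues past compound 3, or that swapping 2-methyl-5-nitro-1H-imidazol-1-yl for (2-methyl-5-nitro-1H-imidazol-1-yl)methyl at this place, a small change of a single carbon, can produce a large step in cytotoxicity.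

From the compounds shown here alone, how far this trend runs remains open, since three chain lengths cannot show whether a longer chain would continue it, and they do not reveal why the number falls. It is also unknown whether the chain's carbon count alone matters, or whether a chain of the same length holding an ether oxygen or an amide would read the same way in this assay.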